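The source may hold more compounds than are shown below. What is called first, only, known or untested is meant among the compounds shown, and "the series" means these compounds.

Compound 1 `CC(C)=CCC1Cc2c(OC(=O)Nc3ccccc3F)cc(=O)n(CCCO)c2CC1(C)C` and compound 2 `CC(C)=CCC/C(C)=C/CC1Cc2c(OCCCOc3ccc(Cl)cc3)cc(=O)n(CCCO)c2CC1(C)C` share one core and were both examined in a functional assay on PANC-1 cells (Homo sapiens) for inhibition, read by MTT assay, with a stated time of 24 h, tested at 10 uM; on this read-out higher numbers stand for more inhibition at the one concentration tested (going by the name of the read-out) and lower numbers for less inhibition. In this assay compound 1 gives 0%, and compound 2 gives 0%, so compound 2 stands level with compound 1 at the digits reported, within the scatter of this kind of measurement. Compound 3 `CC(C)=CCC/C(C)=C/CC1Cc2c(OC(=O)Nc3ccccc3F)cc(=O)n(CCCO)c2CC1(C)C` has not yet been measured. It differs from compound 2 in one place: (2-fluorophenyl)carbamoyl in place of 3-(4-chlorophenoxy)propyl on an oxygen on an aromatic ring. The (2-fluorophenyl)carbamoyl group on an oxygen on an aromatic ring that enters in compound 3 is the same group that compound 1 carries, and compound 1 shows no inhibition. Among the measured compounds shown here, no measured step between these compounds exists, so the size of the change from compound 2 to compound 3 can only be expected, not read. Because compound 1 gives 0% and compound 2 gives 0%, the step from compound 2 to compound 3 is expected to be no change at the digits printed from compound 2 to compound 3 (within the scatter), none beyond the scatter. Compound 3 is thus estimated at 0%, with a range from -8% to 15%.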

Compound 3, a percentage reported as inhibition, at one concentration (the size of the read-out at that concentration, not a potency): 0%
The estimate for compound 3 equals the measured number at the digits printed; low and high end bracket the measured number.
By their numbers in this assay, from the lowest: compounds 1, 2 and 3 (each within the scatter of the next).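

In this assay, (2-fluorophenyl)carbamoyl in place of 3-(4-chlorophenoxy)propyl on an oxygen on an aromatic ring gives no change at the digits printed from compound 2 to compound 3 (within the scatter), so this first readable step at that oxygen shows two quite different groups giving the same reading. The second step, 3-methylbut-2-en-1-yl in place of hydrogen on a saturated chain carbon bound to a double-bonded chain carbon, gives no change at the digits printed from compound 1 to compound 3 (within the scatter), and so the longer side chain also makes no difference to the reading with the carbamoyl group in place. No accompanying measurement offers an explanation for these readings.

Going by these compounds, it remains open whether an amine or a carboxylic acid on this oxygen would give any inhibition. These compounds also leave open whether either step would show a difference at another concentration or exposure time.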